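Changing the Furan Attachment Point on a Second Core

The compounds below may be only part of what the source reports. "The series", "measured", "known", "first", "only" and "open" are said of these compounds alone.

Compound 1 `CC1=C(C(=O)OC(C)(C)C)C(c2ccco2)NC(=S)N1` and compound 2 `CC1=C(C(=O)OC(C)(C)C)C(c2ccoc2)NC(=S)N1` share one core and differ in a single place: furan-3-yl in place of furan-2-yl on a saturated ring carbon. In an assay on membranes from CHO cells for displacement of a labelled ligand from adenosine receptor A1 (Homo sapiens), read by scintillation counting, with a stated time of 60 min, tested at 1 uM (a lower number here means less inhibition, a higher number more inhibition at the concentration tested (going by the name of the read-out)), compound 1 gives 3%, while compound 2 gives 18%, so that a number 15 percentage points higher from compound 1 to compound 2 (beyond the scatter). Compound 3 `CCC(CC)OC(=O)C1=C(C)NC(=O)NC1c1ccco1` rests on a second core; the difference between the two cores is not broken down here. In this assay compound 3 gives 2%, close to compound 1. Compound 4 `CCC(CC)OC(=O)C1=C(C)NC(=O)NC1c1ccoc1` carries the same kind of change applied to compound 3: furan-3-yl in place of furan-2-yl on a saturated ring carbon. The surroundings are not identical, since in compound 3 the ring atom bears a group of 8 heavy atoms rather than 7. Compound 4 is expected to show a step of a number 12 percentage points higher from compound 3 to compound 4 (beyond the scatter) because a number 15 percentage points higher from compound 1 to compound 2 (beyond the scatter) on the first core. Compound 4 is thus estimated at 14%, between 3% and 30%.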

Compound 4, a percentage reported as inhibition, at one concentration (the size of the read-out at that concentration, not a potency): 17%
For compound 4 the middle estimate is 3 percentage points below the measured one; the range from low to high includes it.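

In this assay, furan-3-yl in place of furan-2-yl on the second core gives a number 15 percentage points higher from compound 3 to compound 4 (beyond the scatter). For the compounds shown here, as far as these two pairs go, the change carried over from one core to the other with its size intact: the same change on two cores in this assay, a number 15 percentage points higher (beyond the scatter) from compound 1 to compound 2 and a number 15 percentage points higher (beyond the scatter) from compound 3 to compound 4, 0 percentage points apart, within the scatter of two such steps This agreement rests on only two pairs read at a single concentration, so it gives no potency and does not explain why the steps match or show that the same step would appear on any further core.

The compounds shown leave open whether a thiophene or a pyridine ring in place of the furan would give a similar step. They also leave open how an amine in place of the ester alkoxy group would affect it.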